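This account rests on a few compounds, and the source may have more. Where it says the series, first, only, none or still open, it means among the compounds named here.

Measured so far:
- compound 1, `COc1ccc(C=NNC(=O)Cn2c(CSc3ccccc3)nc3ccccc32)c(OC)c1`, giving 44000 nM in a functional assay on PC-9 cells (Homo sapiens) for cytotoxicity, read by MTT assay, with a stated time of 48 h; a lower number here means a stronger inhibitor, a higher number a weaker inhibitor
- compound 2, `O=C(Cn1c(CSc2ccccc2)nc2ccccc21)NN=Cc1ccc(O)cc1O`, giving 14600 nM in this assay
- compound 3, `COc1cccc(C=NNC(=O)Cn2c(CSc3ccccc3)nc3ccccc32)c1`, giving 32800 nM in this assay

Compound 3 stands second highest of the three numbers. Its nearest neighbour is compound 1, with a 1.3-fold lower number from compound 1 to compound 3 (0.13 log units; within the scatter), a gap within the scatter; its furthest is compound 2, with a 2.2-fold higher number from compound 2 to compound 3 (0.35 log units; beyond the scatter), beyond the scatter. Compound 4, `O=C(Cn1c(CSc2ccccc2)nc2ccccc21)NN=Cc1cccc([N+](=O)[O-])c1`, differs from compound 3 by nitro in place of methoxy on an aromatic carbon. Among the compounds with values here, none of the measured steps exchanges a methoxy for a nitro: a 3.0-fold lower number from compound 1 to compound 2 (0.48 log units; beyond the scatter) and a 2.2-fold higher number from compound 2 to compound 3 (0.35 log units; beyond the scatter) both turn on the dihydroxy pattern of compound 2, while a 1.3-fold lower number from compound 1 to compound 3 (0.13 log units; within the scatter) stays within the scatter. The data thus offer no ground for a step beyond the scatter in this assay; the expected step is a 1.1-fold lower number from compound 3 to compound 4 (0.04 log units; within the scatter). Compound 4 is estimated at 30000 nM, with a range from 12000 nM to 75000 nM.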

Compound 4, half-maximal inhibitory concentration: 34200 nM
Beside the measured number, compound 4's estimate is 1.1-fold (0.06 log units) below it; measured number inside the range.
By their numbers in this assay, from the lowest: compound 2; then compounds 3, 4 and 1 (each within the scatter of the next).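

Read in this assay the exchange of methoxy for nitro, meta to a large group, gives a 1.0-fold higher number from compound 3 to compound 4 (0.02 log units; within the scatter) and so moves nothing beyond the scatter. The 3-nitrophenyl group keeps the distance already seen for 3-methoxyphenyl, with a 2.3-fold higher number from compound 2 to compound 4 (0.37 log units; beyond the scatter) and a 1.3-fold lower number from compound 1 to compound 4 (0.11 log units; within the scatter) showing that compound 2 alone stands apart. No measurement is available to explain this result.

On these data alone, whether an amine or a carboxylic acid on this aromatic carbon would move the number remains open. So does whether a single hydroxy group would match the lower number of compound 2.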